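The source may report more compounds than this note shows. Statements on the series, on what has been measured and on what is new or still open speak of the compounds shown alone.

Of the compounds shown here, three from one series have been tested in a functional assay on A549 cells (Homo sapiens) for cytotoxicity, read by sulforhodamine B assay; a higher number here means a weaker inhibitor, a lower number a stronger inhibitor. Compound 1 `C=C1[C@@H](C/C=C2/C(=O)OC[C@H]2OC(C)=O)[C@]2(C)CC[C@@H](OC(C)=O)[C@@](C)(CO[Si](C)(C)C(C)(C)C)[C@H]2C[C@@H]1O` gives 6850 nM in this assay, and compound 3 `C=C1CC[C@@H]2[C@](C)(CO[Si](C)(C)C(C)(C)C)[C@H](OC(C)=O)CC[C@@]2(C)[C@@H]1C/C=C1/C(=O)OC[C@H]1OC(C)=O` gives 3990 nM. These two differ in a single place, and the step of a 1.7-fold lower number from compound 1 to compound 3 (0.23 log units; within the scatter) is small. Compound 2 `C=C1[C@@H](OC(C)=O)C[C@@H]2[C@](C)(COC=O)[C@H](OC(C)=O)CC[C@@]2(C)[C@@H]1C[C@@H](Nc1ccccc1C(=O)O)C1=CCOC1=O` stands apart: in this assay compound 2 gives 45900 nM, the highest number of the three, and its steps to compound 1 and to compound 3 both lie beyond the usual scatter, so compound 2 is the weakest inhibitor measured so far.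

Compound 4 `C=C1[C@@H](OC(C)=O)C[C@@H]2[C@](C)(COC=O)[C@H](OC(C)=O)CC[C@@]2(C)[C@@H]1C[C@@H](Nc1ccc(OC)cc1)C1=CCOC1=O` has not yet been measured. It differs from compound 2 in one place: 4-methoxyphenyl in place of 2-carboxyphenyl on an amine nitrogen. Among the compounds with values here, the only measured step, the one from compound 1 to compound 3, concerns a different part of the shared core, a hydroxy group on a saturated ring carbon, and says nothing about what a change at the amine nitrogen does. Within the data shown here, no measured step therefore bears on the change from compound 2 to compound 4, and any expectation rests on the starting point alone. With nothing to guide it, the expected step of a 1.8-fold lower number from compound 2 to compound 4 (0.26 log units; within the scatter) in this assay is kept modest and leans toward a lower number. For compound 4 the result in this assay is estimated at 25000 nM, with a range from 6000 nM to 100000 nM.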

Compound 4, half-maximal inhibitory concentration: 28900 nM
Beside the measured number, compound 4's estimate is 1.2-fold (0.06 log units) below it; measured number inside the range.
By their numbers in this assay, from the lowest: compounds 3 and 1 (each within the scatter of the next); then compounds 4 and 2 (each within the scatter of the next).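

In this assay, within the data shown here, placing 4-methoxyphenyl in place of 2-carboxyphenyl on the amine nitrogen gives a 1.6-fold lower number from compound 2 to compound 4 (0.20 log units; within the scatter), which is the first reading at this position, and the step is small enough that the two compounds cannot be told apart. The group that leaves has 1 hydrogen-bond donor and the group that enters has 0 hydrogen-bond donors, yet in this single pair that difference comes with no step beyond the scatter. No measurement shown here explains why the two aryl groups read so much alike, so the result stands as an observation about this one pair, without a known cause.

Both groups on this nitrogen are substituted phenyl rings, so one pair cannot show whether the position tolerates change in general or whether a non-aromatic group, such as a cyclohexyl ring or a plain ethyl chain, would read the same. Going by these compounds, it also remains open how an unsubstituted phenyl or a 4-carboxyphenyl group would compare, and so whether the identity or the location of the substituent on the ring matters at all.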